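Trimming a Two-Ring Ether Substituent to a Single Pyridine

This account rests on a few compounds, and the source may have more. Where it says the series, first, only, none or still open, it means among the compounds named here.

Compound 1 `CC(C)(C)Sc1c(CC(C)(C)C(=O)O)n(Cc2ccc(Cl)cc2)c2ccc(OCc3ccc4cnccc4n3)cc12` is a carboxylic acid whose shared core carries an aryl ether, and in a functional assay for inhibition, with Homo sapiens as the target (a higher number here means a weaker inhibitor, a lower number a stronger inhibitor), compound 1 gives 3 nM. Two close relatives are known: compound 2 `CC(C)(C)Sc1c(CC(C)(C)C(=O)O)n(Cc2ccc(Cl)cc2)c2ccc(OCc3cccnc3)cc12` gives 8 nM, and compound 3 `CC(C)(C)Sc1c(CC(C)(C)C(=O)O)n(Cc2ccc(Cl)cc2)c2ccc(OCc3cccc(Cl)n3)cc12` gives 3 nM. Compound 1 stands level with compound 3 at the digits shown, the two together lowest of the three, while compound 2 lies furthest away.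

Compound 4 `C[C@@H](COc1ccc2c(c1)c(SC(C)(C)C)c(CC(C)(C)C(=O)O)n2Cc1ccc(Cl)cc1)c1ccccn1` differs from compound 1 in one place: a group of 8 heavy atoms (7 carbon, 1 nitrogen; one six-membered aromatic ring with 1 hetero atom) in place of a group of 10 heavy atoms (8 carbon, 2 nitrogen; 2 six-membered aromatic rings with 1 hetero atom each), on a saturated chain carbon bound to an oxygen on an aromatic ring. The entering 1-(pyridin-2-yl)ethyl group has one six-membered aromatic ring with one hetero atom, as do the groups in compounds 2 and 3, so two measured steps bear on it: a 2.7-fold higher number from compound 1 to compound 2 (0.43 log units; beyond the scatter) and no change at the digits printed from compound 1 to compound 3 (within the scatter). Cutting the two-ring group down to one ring thus cost either nothing or a modest step. Among the compounds with values here, no measured compound carries a defined stereocentre in this group, so that feature is untested. Compound 4 is therefore expected to sit near compound 1 or slightly weaker, a 1.7-fold higher number from compound 1 to compound 4 (0.22 log units; within the scatter). The estimate for compound 4 is 5 nM, with a range from 2 nM to 15 nM.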

Compound 4, half-maximal inhibitory concentration: 2 nM
Compound 4: middle estimate off by 2.5-fold (0.40 log units), on the high side; the measured number falls inside the stated range.
By their numbers in this assay, from the lowest: compounds 4, 1 and 3 (each within the scatter of the next); then compound 2.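

Within the data shown here, the 1-(pyridin-2-yl)ethyl group is the first group here with a defined stereocentre, and in this assay it shows that a single unsubstituted pyridine ring on this saturated chain carbon can hold up as well as the two-ring group, with a 1.5-fold lower number from compound 1 to compound 4 (0.18 log units; within the scatter). The same group also matches the 6-chloropyridin-2-yl group, with a 1.5-fold lower number from compound 3 to compound 4 (0.18 log units; within the scatter), so no chlorine is needed on the ring to stay at this level. Against the pyridin-3-yl group the difference is real, with a 4.0-fold lower number from compound 2 to compound 4 (0.60 log units; beyond the scatter), which leaves compound 2 alone at the weaker end of the four.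

The compounds shown cannot separate the effects of the stereocentre, the added carbons and the ring's point of attachment, which the mirror-image form or a plain pyridin-2-yl group on the same carbon would begin to pull apart. Nothing available accounts for any of these differences.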